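Iodo to Nitro Next to a Large Group: Expected Step

The source may hold more compounds than are shown below. What is called first, only, known or untested is meant among the compounds shown, and "the series" means these compounds.

Of the compounds shown here, three have been tested in a functional assay on U-87MG ATCC cells (Homo sapiens) for cytotoxicity, read by MTT assay, with a stated time of 48 h; a higher number here means a weaker inhibitor, a lower number a stronger inhibitor. Compound 1 `CC(=NNC(=S)Nc1cccc([N+](=O)[O-])c1)c1ccccn1` gives 69 nM, compound 2 `CC(=NNC(=S)Nc1cccc(I)c1)c1ccccn1` gives 84 nM, and compound 3 `C/C(=N/NC(=S)Nc1ccccc1I)c1ccccn1` gives 6.1 nM, the lowest number of the three and beyond the scatter from both others. Compound 4 `C/C(=N/NC(=S)Nc1ccccc1[N+](=O)[O-])c1ccccn1` has not yet been measured. The difference between the core of compound 2 and the core of compound 3 is not broken down here. From compound 2 to compound 1 one change is made: nitro in place of iodo on an aromatic carbon That step was a 1.2-fold lower number from compound 2 to compound 1 (0.09 log units; within the scatter). The same kind of change leads from compound 3 to compound 4: nitro in place of iodo on an aromatic carbon The place is not identical: meta to a large group in the first pair, ortho to a large group in the second. Because the earlier step of a 1.2-fold lower number from compound 2 to compound 1 (0.09 log units; within the scatter) stayed within the scatter, the step in this assay is expected to be a 1.1-fold higher number from compound 3 to compound 4 (0.06 log units; within the scatter), with the different place adding some uncertainty. Compound 4 is therefore expected near 7 nM, likely between 3 nM and 20 nM.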

Compound 4, half-maximal inhibitory concentration: 4.3 nM
Beside the measured number, compound 4's estimate is 1.6-fold (0.21 log units) above it; low and high end bracket the measured number.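

In this assay, putting nitro in place of iodo on the aromatic carbon ortho to a large group gives a 1.4-fold lower number from compound 3 to compound 4 (0.15 log units; within the scatter). Set beside the same change on the other core, the step carries over well: the same change on two cores in this assay, a 1.2-fold lower number (0.09 log units; within the scatter) from compound 2 to compound 1 and a 1.4-fold lower number (0.15 log units; within the scatter) from compound 3 to compound 4, 1.2-fold (0.07 log units) apart, within the scatter of two such steps This shows only that, in these two pairs, the swap leaves the number within the scatter; it does not show that the same would hold on other cores, or say what either group does in the cells.

The compounds shown leave open how other groups in that place would behave, such as an amine, a carboxylic acid or a longer chain. They also do not break down the difference between the two cores.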